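One methoxy group added to a weak inhibitor

This account rests on a few compounds, and the source may have more. Where it says the series, first, only, none or still open, it means among the compounds named here.

- Compound 1 `COc1ccc2[nH]c(-c3ccc[nH]3)c(C3CC(=O)NC3=O)c2c1`: 4000 nM
- Compound 2 `c1ccc2[nH]c(-n3cccn3)cc2c1`: 86000 nM
- Compound 3 `COc1ccc2[nH]c3c(c4c(c5ccnn53)C(=O)NC4=O)c2c1`: 34000 nM

These three compounds were tested in a functional assay on LoVo cells (Homo sapiens) for cytotoxicity, read by MTT assay, with a stated time of 72 h; a lower number here means a stronger inhibitor, a higher number a weaker inhibitor. Compound 2 gives 86000 nM, the highest number of the three, which makes it the weakest inhibitor of the set. Its gaps to the other two both lie beyond the scatter. Compound 3 comes nearest at 34000 nM, and compound 1 lies furthest away at 4000 nM.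

Compound 4 `COc1ccc2[nH]c(-n3cccn3)cc2c1` has not yet been measured. It differs from compound 2 by one change, with methoxy in place of hydrogen on an aromatic carbon of a six-membered aromatic ring of carbon only: methoxy in place of hydrogen on an aromatic carbon.

For the measured compounds named here, no two measured compounds differ in one place only, so the data hold no direct measure of this change. Compound 1 and compound 3 both carry a methoxy group and both give lower numbers than compound 2, but they also differ from it in other ways. That offers only weak support for a small step towards a lower number in this assay, probably not beyond the scatter.

The estimated change is a 1.6-fold lower number from compound 2 to compound 4 (0.19 log units; within the scatter). For compound 4 the expected value is 55000 nM, with an estimated range of 20000 nM to 110000 nM.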

Compound 4, half-maximal inhibitory concentration: 70000 nM
Compound 4: the middle estimate sits 1.3-fold (0.10 log units) below what was measured; the measured number falls inside the stated range.
By their numbers in this assay, from the lowest: compound 1; then compound 3; then compounds 4 and 2 (each within the scatter of the next).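

In this assay, for the compounds shown here, the first direct reading of this change gives a 1.2-fold lower number from compound 2 to compound 4 (0.09 log units; within the scatter), so methoxy in place of hydrogen on an aromatic carbon, on the six-membered aromatic ring of carbon only, meta to a fused ring and para to a fused ring, does not separate the two compounds on this core. Compound 1 and compound 3 also carry a methoxy group and have lower numbers, but this pair gives no support for reading that group as a route to a lower number, and their other differences remain unresolved. No measured evidence speaks to the reason for this result.

From the compounds shown here alone, it remains open whether another group on this aromatic carbon, such as an amine, a carboxylic acid or a longer chain such as butoxy, would move the number beyond the scatter, and whether methoxy elsewhere on the same ring would behave alike. The compounds shown also leave open whether the same change would give a different step on the core of compound 1 or the core of compound 3.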